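Trifluoromethyl for Chloro, Read on Two Different Cores

A few compounds are considered here, and "the series" means these few. Any claim that something is new, unique, unknown or untested is made for them only; others in the source may bear on it.

Measured compounds in a functional assay on MCF7 cells (Homo sapiens) for inhibition, read by MTT assay, with a stated time of 72 h; a higher number here means a weaker inhibitor, a lower number a stronger inhibitor:
compound 1, `COc1cc(-c2nc(SCc3cn(CC(=O)NC(=O)Nc4ccccn4)nn3)nc(Nc3cccc(C(F)(F)F)c3)c2C#N)cc(OC)c1OC`, gives 8140 nM
compound 2, `COc1cc(-c2nc(SCc3cn(CC(=O)NC(=O)Nc4ccccn4)nn3)nc(Nc3cccc(Cl)c3)c2C#N)cc(OC)c1OC`, gives 24000 nM
compound 3, `Cc1ccc(-c2nc(SCc3cn(CC(=O)NC(=O)Nc4ccccn4)nn3)nc(Nc3cccc(Cl)c3)c2C#N)cc1`, gives 14900 nM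

Compound 2 and compound 3 share everything but the group on the core, where the difference is 4-methylphenyl in place of 3,4,5-trimethoxyphenyl on an aromatic carbon. This exchange gave a 1.6-fold lower number from compound 2 to compound 3 (0.21 log units; within the scatter), so the two cores cannot be separated by this assay. Compound 1 differs from compound 2 by trifluoromethyl in place of chloro on an aromatic carbon, and that step was a 2.9-fold lower number from compound 2 to compound 1 (0.47 log units; beyond the scatter).

Compound 4, `Cc1ccc(-c2nc(SCc3cn(CC(=O)NC(=O)Nc4ccccn4)nn3)nc(Nc3cccc(C(F)(F)F)c3)c2C#N)cc1`, is not yet measured. It differs from compound 3 by trifluoromethyl in place of chloro on an aromatic carbon, the same change that turned compound 2 into compound 1, at the same place, meta to a large group on the six-membered aromatic ring of carbon only. Because compound 3 stands at 14900 nM and because the earlier step was a 2.9-fold lower number from compound 2 to compound 1 (0.47 log units; beyond the scatter), a step of similar size is expected for compound 4, namely a 2.7-fold lower number from compound 3 to compound 4 (0.43 log units; beyond the scatter). Compound 4 is therefore estimated at 5500 nM in this assay, with a likely range from 2200 nM to 14000 nM.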

Compound 4, half-maximal inhibitory concentration: 6120 nM
Estimate against measurement, compound 4: 1.1-fold (0.05 log units) below; low and high end bracket the measured number.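

In this assay, trifluoromethyl in place of chloro gave a 2.4-fold lower number from compound 3 to compound 4 (0.39 log units; beyond the scatter), and the step carried from one core to the other at much the same size: the same change on two cores in this assay, a 2.9-fold lower number (0.47 log units; beyond the scatter) from compound 2 to compound 1 and a 2.4-fold lower number (0.39 log units; beyond the scatter) from compound 3 to compound 4, 1.2-fold (0.08 log units) apart, within the scatter of two such steps. Read the other way, 4-methylphenyl in place of 3,4,5-trimethoxyphenyl gave a 1.3-fold lower number from compound 1 to compound 4 (0.12 log units; within the scatter), so the two cores remain inseparable in this assay whether the aniline ring carries chloro or trifluoromethyl: the same change on two cores in this assay, a 1.6-fold lower number (0.21 log units; within the scatter) from compound 2 to compound 3 and a 1.3-fold lower number (0.12 log units; within the scatter) from compound 1 to compound 4, 1.2-fold (0.08 log units) apart, within the scatter of two such steps. Across these four compounds the two exchanges behave as independent of each other, but this rests on a single pair of cores in a single cell line, and it shows neither that the step would hold on a further core nor why trifluoromethyl gives the lower number.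

The compounds shown leave open whether a bromo or a methoxy group in the same place would follow chloro or trifluoromethyl, or neither. They also leave open whether the step would survive on a core carrying an unsubstituted phenyl group, or with a carboxylic acid in place of the urea end of the side chain.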